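The source may hold more compounds than are shown below. What is called first, only, known or untested is meant among the compounds shown, and "the series" means these compounds.

Series measured in a functional assay on CNE-2 cells (Homo sapiens) for inhibition, read by MTT assay, with a stated time of 72 h; on this read-out lower numbers stand for stronger inhibition and higher numbers for weaker inhibition:
- compound 1 `Nc1ncnc2c1c(-c1cnc3[nH]ccc3c1)nn2CCCCCC(=O)NO`: > 50000 nM (a limit)
- compound 2 `Nc1nc2cc(-c3nn(CCC(=O)NO)c4ncnc(N)c34)ccc2o1`: > 150000 nM (a limit)
- compound 3 `Nc1ncnc2c1c(-c1cnc3[nH]ccc3c1)nn2CCCCCCC(=O)NO`: 19500 nM

Compound 1 gives > 50000 nM, which is a limit and not a number. As far as these compounds go, compound 2 stands at the limit of > 150000 nM in this assay, at which 1 of the 3 values shown sits, also a limit and not a number, so its true position is unknown. Compound 3 is the only one of the three with a number.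

The next compound is compound 4 `CNC(=O)CCCCCCCn1nc(-c2ccc3oc(N)nc3c2)c2c(N)ncnc21`. The change from compound 2 is 5-(methylcarbamoyl)pentyl in place of hydroxycarbamoyl on a saturated chain carbon, two bonds along the chain from an aromatic nitrogen. Here 5-(methylcarbamoyl)pentyl stands in place of hydroxycarbamoyl.

For the measured compounds named here, one measured step bears on this, and only in part: an at least 2.5-fold lower number from compound 1 to compound 3 (0.40 log units; beyond the scatter). It is at least modest and beyond the scatter, but it comes from a different core and keeps the hydroxycarbamoyl end. Going by the values given here, no measured step covers the exchange of that end for methylcarbamoyl.

On the evidence of an at least 2.5-fold lower number from compound 1 to compound 3 (0.40 log units; beyond the scatter), a lower number is tentatively expected in this assay, and a reading that gives only a limit remains quite possible. The expected change is an at least 2.5-fold lower number from compound 2 to compound 4 (0.39 log units; beyond the scatter). For compound 4 the estimated value is 60000 nM, with an expected range of 15000 nM to 200000 nM.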

Compound 4, half-maximal inhibitory concentration: 2250 nM
For compound 4 the middle estimate is 27-fold (1.43 log units) above the measured one; measured number outside the range, below it.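

In this assay, replacing hydroxycarbamoyl with 5-(methylcarbamoyl)pentyl on a saturated chain carbon, two bonds along the chain from an aromatic nitrogen, gives an at least 66-fold lower number from compound 2 to compound 4 (1.82 log units; beyond the scatter). This shows that the hydroxycarbamoyl end can be given up at this position without loss of a measurable value on this core, whereas the earlier step changed the chain and kept that end. The size of the step is only a bound, since the value for compound 2 is a limit and not a number: the limit of > 150000 nM in this assay, at which 1 of the 4 values shown sits.

The exchange changes chain length and end group together, so the compounds shown do not separate the contribution of each. Also open, as far as these compounds go, is how a carboxylic acid or an amine at the end of the same longer chain would read in this assay.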